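A few compounds are considered here, and "the series" means these few. Any claim that something is new, unique, unknown or untested is made for them only; others in the source may bear on it.

Working notes on the series. Compound 2 `Fc1ccc(Nc2nccc(-c3ccncc3)n2)cc1` gives 1900 nM in a functional assay for inhibition, with Homo sapiens as the target; on this read-out lower numbers stand for stronger inhibition and higher numbers for weaker inhibition. Compound 1 `COc1cccc(Nc2nccc(-c3cccs3)n2)c1` gives 900 nM, and compound 3 `CN(C)c1cccc(Nc2nccc(-c3cccs3)n2)c1` gives 2400 nM; compound 2 thus sits between the two, within the scatter of compound 3 and separated from compound 1 by a gap beyond the scatter. Among the measured compounds shown here, the one measured step, a 2.7-fold higher number from compound 1 to compound 3 (0.43 log units; beyond the scatter), concerns dimethylamino in place of methoxy on an aromatic carbon of the shared core, a change unrelated to the one under study. Compound 4 `CCc1ccc(Nc2nccc(-c3ccncc3)n2)cc1` differs from compound 2 by ethyl in place of fluoro on an aromatic carbon. For the measured compounds named here, no measured step bears on ethyl in place of fluoro, so no step beyond the scatter is expected, as no change at the digits printed from compound 2 to compound 4 (within the scatter). Compound 4 is therefore estimated at 1900 nM, within a range of 700 nM to 5000 nM.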

Compound 4, half-maximal inhibitory concentration: 7700 nM
Compound 4: the middle estimate sits 4.1-fold (0.61 log units) below what was measured; the whole stated range lies below it.
By their numbers in this assay, from the lowest: compound 1; then compounds 2 and 3 (each within the scatter of the next); then compound 4.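

Ethyl in place of fluoro, on an aromatic carbon para to a large group, is the first change at this position with a measured step, and it gives a 4.1-fold higher number from compound 2 to compound 4 (0.61 log units; beyond the scatter) in this assay. Among the compounds shown here, the position therefore does not tolerate this change without a shift beyond the scatter, which the earlier compounds could not show. No evidence on hand bears on the origin of this step.

From the compounds shown here alone, whether methyl, a longer chain such as propyl, or an amine at this position would give a number nearer compound 2 or compound 4 remains open. Also open, going by these compounds, is whether the same change gives a similar step on the core of compound 1.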